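The compounds below may be only part of what the source reports. "The series", "measured", "known", "first", "only" and "open" are said of these compounds alone.

The series shares one core, seen in compound 1 `O=C(O)CCC(=O)OCCCCCCSc1ccc([N+](=O)[O-])c2nonc12`; in an assay on isolated protein for inhibition of glutathione S-transferase P (Homo sapiens), with a stated time of 10 min (on this read-out lower numbers stand for stronger inhibition and higher numbers for weaker inhibition), compound 1 gives 530 nM. Compound 2 `O=C(CCC(=O)OCCCCCCSc1ccc([N+](=O)[O-])c2nonc12)Nc1ccccc1F` gives 9890 nM and compound 3 `COc1ccc(NC(=O)CCC(=O)OCCCCCCSc2ccc([N+](=O)[O-])c3nonc23)cc1OC` gives 6470 nM. Compound 2 thus carries the highest number of the three: its gap to compound 3 is within the scatter, while a 19-fold higher number from compound 1 to compound 2 (1.27 log units; beyond the scatter) and a 12-fold higher number from compound 1 to compound 3 (1.09 log units; beyond the scatter) were both large. Compound 4 `O=C(CCC(=O)N1CCCCC1)OCCCCCCSc1ccc([N+](=O)[O-])c2nonc12` is not yet measured and differs from compound 2 in one place: piperidin-1-yl in place of (2-fluorophenyl)amino on a carbonyl carbon. Among the measured compounds shown here, no measured step makes this kind of exchange; the only step among the amides, a 1.5-fold lower number from compound 2 to compound 3 (0.18 log units; within the scatter), moved little. Compound 4 is therefore expected to stay about where the two amides sit, giving a 1.4-fold lower number from compound 2 to compound 4 (0.15 log units; within the scatter) as an expected step within the scatter. Compound 4 is estimated at 7000 nM, range 2500 nM to 20000 nM.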

Compound 4, half-maximal inhibitory concentration: 500 nM
Compound 4: the middle estimate sits 14-fold (1.15 log units) above what was measured, and the stated range ends above it.
By their numbers in this assay, from the lowest: compounds 4 and 1 (each within the scatter of the next); then compounds 3 and 2 (each within the scatter of the next).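

The large rise seen with (2-fluorophenyl)amino and (3,4-dimethoxyphenyl)amino on this carbonyl carbon does not hold for every amide: piperidin-1-yl reverses it (a 20-fold lower number from compound 2 to compound 4 (1.30 log units; beyond the scatter); a 13-fold lower number from compound 3 to compound 4 (1.11 log units; beyond the scatter)) and stays level with the hydroxy of the free carboxylic acid (a 1.1-fold lower number from compound 1 to compound 4 (0.03 log units; within the scatter)). The carboxylic acid is therefore not needed at this position, at least in compound 4. No supporting measurement explains these steps.

Going by these compounds, the exchange removes the amide hydrogen and the aromatic ring together, so their separate contributions remain open. Cyclohexylamino, which keeps that hydrogen without an aromatic ring, would help separate them.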